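A small ring added to compound 3

The source may hold more compounds than are shown below. What is called first, only, known or untested is meant among the compounds shown, and "the series" means these compounds.

Values in a physicochemical assay for solubility, read by LC-MS, in phosphate buffer, with a stated time of 24 h, at pH 7.4; on this read-out higher numbers stand for higher solubility and lower numbers for lower solubility:
- Compound 1 `O=C(Nc1ccccc1)c1cnc(NCc2c(F)ccc3c2CCO3)n2cnnc12`: < 1000 nM (a limit)
- Compound 2 `CN(c1ccccc1)c1cnc(NCc2c(F)ccc3c2CCO3)n2cnnc12`: < 2000 nM (a limit)
- Compound 3 `C[C@H]1CC(=O)N(c2cnc(NCc3c(F)ccc4c3CCO4)n3cnnc23)C1`: 200000 nM

Of these three entries, only compound 3 has a true number, 200000 nM. The other two entries are limits. The two steps that bear on the next change are an at least 200-fold higher number from compound 1 to compound 3 (2.30 log units; beyond the scatter) and an at least 100-fold higher number from compound 2 to compound 3 (2.00 log units; beyond the scatter), both large, and both bring in 4-methyl-2-oxopyrrolidin-1-yl. Compound 4 `O=C1CC2(CC2)CN1c1cnc(NCc2c(F)ccc3c2CCO3)n2cnnc12` alters that group: a group of 8 heavy atoms (6 carbon, 1 nitrogen, 1 oxygen; one three-membered non-aromatic ring of carbon only, one five-membered non-aromatic ring with 1 hetero atom) in place of a group of 7 heavy atoms (5 carbon, 1 nitrogen, 1 oxygen; one five-membered non-aromatic ring with 1 hetero atom), on an aromatic carbon. The five-membered non-aromatic ring with 1 hetero atom stays, so no step beyond the scatter is expected in this assay, after an at least 100-fold higher number from compound 2 to compound 3 (2.00 log units; beyond the scatter) brought that ring in. The estimated change is a 1.7-fold lower number from compound 3 to compound 4 (0.22 log units; within the scatter). For compound 4 the expected value is 120000 nM, with an estimated range of 40000 nM to 300000 nM.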

Compound 4, solubility: 130000 nM
The estimate for compound 4 lay 1.1-fold (0.03 log units) below the measured number; measured number inside the range.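

In this assay, replacing 4-methyl-2-oxopyrrolidin-1-yl with the ring carrying a three-membered ring of carbon only gives a 1.5-fold lower number from compound 3 to compound 4 (0.19 log units; within the scatter), so this position takes the added ring and the loss of the defined stereocentre without a readable change. The large gain over the earlier groups also survives this change: an at least 65-fold higher number from compound 2 to compound 4 (1.81 log units; beyond the scatter), and an at least 130-fold higher number from compound 1 to compound 4 (2.11 log units; beyond the scatter). Both of those steps start from limits rather than true numbers, held by compound 1 and compound 2.

Still open, going by these compounds, is how a hydroxyl or an amine on the five-membered ring, in place of the three-membered ring, would read in this assay.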